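The source may hold more compounds than are shown below. What is called first, only, known or untested is meant among the compounds shown, and "the series" means these compounds.

Measured so far in a functional assay on CCRF-CEM cells (Homo sapiens) for inhibition, read by MTT assay, with a stated time of 72 h; a higher number here means a weaker inhibitor, a lower number a stronger inhibitor:
- compound 1 `COc1cc(NC(C)CCCNC(=O)Nc2ccc(F)cc2)c2ncccc2c1`: 26000 nM
- compound 2 `COc1cc(NC(C)CCCNC(=O)NNC(=O)Nc2cccc(F)c2)c2ncccc2c1`: 98000 nM

Of these two compounds, compound 2 has the higher number, and compound 1 is therefore its nearest neighbour. The next compound to consider is compound 3 `COc1cc(NC(C)CCCNC(=O)Nc2ccc(C(F)(F)F)cc2)c2ncccc2c1`, which differs from compound 2 by 4-(trifluoromethyl)phenyl in place of ((3-fluorophenyl)carbamoyl)amino on an amide-type nitrogen. The change lies on an amide-type nitrogen whose other neighbour is a carbonyl carbon.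

Among the compounds with values here, only one measured step bears on this change: a 3.8-fold higher number from compound 1 to compound 2 (0.58 log units; beyond the scatter). That step was modest but beyond the scatter, and ((3-fluorophenyl)carbamoyl)amino entered in it. Here the same group leaves, so a step of similar size in the opposite direction is expected, toward a lower number in this assay. Within the data shown here, no measured compound carries 4-(trifluoromethyl)phenyl, so the size of the step remains uncertain and the range is kept wide. The expected change is a 4.5-fold lower number from compound 2 to compound 3 (0.65 log units; beyond the scatter). For compound 3 the estimated value is 22000 nM, with an expected range from 8000 nM to 60000 nM.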

Compound 3, half-maximal inhibitory concentration: 14000 nM
Beside the measured number, compound 3's estimate is 1.6-fold (0.20 log units) above it; low and high end bracket the measured number.
By their numbers in this assay, from the lowest: compounds 3 and 1 (each within the scatter of the next); then compound 2.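

In this assay, 4-(trifluoromethyl)phenyl in place of ((3-fluorophenyl)carbamoyl)amino on the amide-type nitrogen gives a 7.0-fold lower number from compound 2 to compound 3 (0.85 log units; beyond the scatter), so compound 2, the only one of the three carrying ((3-fluorophenyl)carbamoyl)amino, now stands beyond the scatter from both other compounds, with the higher number in each case. Trifluoromethyl in place of fluoro on the aromatic carbon gives a 1.9-fold lower number from compound 1 to compound 3 (0.27 log units; within the scatter), which lies within the scatter, so this assay does not separate these two substituents, and the series so far shows a response to the larger change on this nitrogen but none beyond the scatter to the smaller one. Nothing at hand gives a measured reason for either step.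

Still open is how much of the step to compound 2 belongs to the added carbamoylamino stretch and how much to the 3-fluorophenyl in place of a 4-substituted phenyl, as the shown compounds change both together. Also open, going by these compounds, is how this nitrogen would respond to a phenyl carrying an amine or a carboxylic acid, or to a longer chain in place of the phenyl.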